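The source may report more compounds than this note shows. Statements on the series, on what has been measured and on what is new or still open speak of the compounds shown alone.

Compound 2 `CCC(C)N(c1ccnc(Nc2ccc(C#N)cc2)n1)c1c(F)cc(-c2ccc(C#N)cc2)cc1F` and compound 1 `CN(c1ccnc(Nc2ccc(C#N)cc2)n1)c1c(F)cc(-c2ccc(C#N)cc2)cc1F` share one core and differ only in the group on a nitrogen on an aromatic ring, a sec-butyl in compound 2 and a methyl in compound 1. In an ADME assay on MT4 cells (Homo sapiens) for cytotoxicity, read by MTT assay, with a stated time of 5 days (on this read-out lower numbers stand for higher toxicity in this test and higher numbers for lower toxicity in this test), compound 1 gives 148000 nM, and in this assay compound 2 gives 217000 nM. Compound 2 stands alongside compound 1, the two numbers within the usual scatter of each other, as the step of a 1.5-fold higher number from compound 1 to compound 2 (0.17 log units; within the scatter) shows. Compound 3 `N#Cc1ccc(Nc2nccc(N(CCCF)c3c(F)cc(-c4ccc(C#N)cc4)cc3F)n2)cc1`, not yet measured, carries 3-fluoropropyl in place of sec-butyl on a nitrogen on an aromatic ring. For the measured compounds named here, only one measured step bears on this place, and it shows that exchanging the group on this nitrogen left this assay essentially unchanged. A 3-fluoropropyl group there is therefore expected to give no step beyond the scatter, a 1.1-fold lower number from compound 2 to compound 3 (0.04 log units; within the scatter). Compound 3 is estimated at 200000 nM, with a range from 100000 nM to 400000 nM.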

Compound 3, half-maximal cytotoxic concentration: 241000 nM
Beside the measured number, compound 3's estimate is 1.2-fold (0.08 log units) below it, within the range that was stated.
By their numbers in this assay, from the lowest: compounds 1, 2 and 3 (each within the scatter of the next).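

Until now only groups of carbon and hydrogen stood on this nitrogen. Compound 3 puts a fluorine-bearing chain there, and in this assay exchanging the branched sec-butyl for the straight 3-fluoropropyl gives (a 1.1-fold higher number from compound 2 to compound 3 (0.05 log units; within the scatter)), while the wider exchange from the methyl gives (a 1.6-fold higher number from compound 1 to compound 3 (0.21 log units; within the scatter)), so all three groups now lie within the scatter of one another. Nothing shown gives a reason for this likeness.

Open, going by these compounds, is whether the same would hold for a chain ending in an amine or a carboxylic acid, or for a much longer chain on this nitrogen. The compounds shown also say nothing about a ring placed there, or about changes elsewhere on the shared core.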